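The source may report more compounds than this note shows. Statements on the series, on what has been measured and on what is new or still open speak of the compounds shown alone.

Compound 1 `COc1ccc(C2C(C#N)=C(N)OC(c3c[nH]c4ccccc34)=C2C#N)cc1OC` and compound 2 `N#CC1=C(N)OC(c2c[nH]c3ccccc23)=C(C#N)C1c1ccccc1Cl` share one core and differ only in the aryl group on a saturated ring carbon. In a functional assay, tested at 50 ug/mL (on this read-out lower numbers stand for a weaker effect and higher numbers for a stronger effect at the one concentration tested), compound 1 gives 14.5%, the higher of the two numbers shown, but only within the scatter, while compound 2 gives 8.5%; the step of a number 6 percentage points lower from compound 1 to compound 2 (within the scatter) confirms this. Compound 3 `N#CC1=C(N)OC(c2c[nH]c3ccccc23)=C(C#N)C1c1ccc(F)cc1` differs from compound 1 by 4-fluorophenyl in place of 3,4-dimethoxyphenyl on a saturated ring carbon. Going by the values given here, only that one measured aryl swap bears on this change, and it stayed within the scatter, so no step beyond the scatter is expected here. Compound 3 is therefore estimated at 12%, between 4% and 22%. The expected step is a number 2.5 percentage points lower from compound 1 to compound 3 (within the scatter).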

Compound 3, a percentage reported as activity, at one concentration (the size of the read-out at that concentration, not a potency): 8.4%
The estimate for compound 3 lay 3.6 percentage points above the measured number; measured number inside the range.
By their numbers in this assay, from the lowest: compounds 3, 2 and 1 (each within the scatter of the next).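

In this assay the 4-fluorophenyl group gives a number 6.1 percentage points lower from compound 1 to compound 3 (within the scatter) and, set against 2-chlorophenyl, a number 0.1 percentage points lower from compound 2 to compound 3 (within the scatter). A third aryl group on this saturated ring carbon therefore also fails to separate from the others, so these three aryl groups cannot be ranked on this read-out. No measurement on hand explains these numbers. Still open, going by these compounds, is whether a group of another kind at this carbon, such as a carboxylic acid on the phenyl ring or a longer alkyl chain in its place, would give a step beyond the scatter.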